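Ethoxy in place of tert-butyl: compound 1 to compound 4

The source may hold more compounds than are shown below. What is called first, only, known or untested is meant among the compounds shown, and "the series" means these compounds.

Compound 1 `COc1cc(/C=C\c2ccc(C(C)(C)C)cc2)cc(OC)c1OC`: 4.32 uM
Compound 2 `COC(=O)/C(=C/c1cccc(OC)c1)c1cc(OC)c(OC)c(OC)c1`: 15.5 uM
Compound 3 `COc1cc(/C=C/c2ccc(C(C)(C)C)cc2)cc(OC)c1OC`: > 25 uM

In a functional assay on MLM cells (Homo sapiens) for cytotoxicity, using microsomes (a lower number here means that less compound is needed, a higher number that more compound is needed for the effect), compound 1 gives 4.32 uM, the lower of the two actual numbers, and compound 2 gives 15.5 uM, a gap beyond the scatter. Compound 3 reads > 25 uM, which is a limit of the assay and not a number.

The next compound to be tested is compound 4 `CCOc1ccc(/C=C\c2cc(OC)c(OC)c(OC)c2)cc1`. Its change from compound 1 is ethoxy in place of tert-butyl on an aromatic carbon, para to a large group. Among the measured compounds shown here, the only measured step is an at least 5.7-fold higher number from compound 1 to compound 3 (0.76 log units; beyond the scatter), and it comes with the fact that compounds 1 and 3 differ only in the configuration as drawn and (the limit of > 25 uM in this assay, at which 1 of the 3 values shown sits). For the measured compounds named here, that step concerns the double bond, not the exchanged group, so no measured step gives the size or direction of this change in this assay. Compound 4 keeps the Z double bond of compound 1, which gives 4.32 uM, so a rise of the kind seen with the E double bond is not expected. The expected step is a 1.7-fold lower number from compound 1 to compound 4 (0.24 log units; within the scatter), so no clear change is anticipated, although the range stays wide. For compound 4 the estimated value is 2.5 uM, with an expected range from 0.3 uM to 12 uM.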

Compound 4, concentration for half-maximal effect: 2.9 uM
Compound 4: middle estimate off by 1.2-fold (0.06 log units), on the low side; the measured number falls inside the stated range.
By their numbers in this assay, from the lowest: compounds 4 and 1 (each within the scatter of the next); then compound 2. At a limit, above all of these: compound 3.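

In this assay, ethoxy in place of tert-butyl on an aromatic carbon, para to a large group, gives a 1.5-fold lower number from compound 1 to compound 4 (0.17 log units; within the scatter), so this exchange leaves the reading indistinguishable from that of the parent while the Z double bond stays in place. Among the compounds shown here, the only earlier step, an at least 5.7-fold higher number from compound 1 to compound 3 (0.76 log units; beyond the scatter), rests on a limit and concerned the double bond, so this is the first reading of what this position tolerates: a group with carbon only and a group carrying an oxygen and a hydrogen-bond acceptor give numbers within the scatter of each other. Nothing measured here explains why the two groups read alike.

For the compounds shown here, whether an amine, a carboxylic acid or a longer chain at this same place would also stay within the scatter of compound 1 remains open, since tert-butyl and ethoxy are the only two groups compared there. Also open is whether ethoxy would read the same with the E double bond, as the only E compound shown with this core carries tert-butyl.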